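Defluorination of the biphenyl tail in a cyclic amidine series

The source may report more compounds than this note shows. Statements on the series, on what has been measured and on what is new or still open speak of the compounds shown alone.

Measured compounds:
Compound 1, `CN(C)CCCCCSC1=Nc2ccccc2C(CC(=O)NCc2ccccc2)N1c1ccc(-c2ccc(F)cc2)cc1`, in a functional assay on HCT-116 cells (Homo sapiens) for cytotoxicity, read by MTT assay, with a stated time of 48 h; a higher number here means a weaker inhibitor, a lower number a stronger inhibitor: compound 1 gives 9200 nM.
Compound 2, `O=C(CC1c2ccccc2N=C(SCCCCCN2CCCC2)N1c1ccc(-c2ccccc2)cc1)NCc1ccc(F)cc1`, in this assay: compound 2 gives 6200 nM.

Within the data shown here, compound 1 holds the higher of the two numbers measured so far in this assay; its nearest neighbour is compound 2, and the gap between the two lies within the scatter of repeated runs, so no order between them is claimed. The two compounds differ at several places at once (the terminal amine, the benzyl amide, and the biphenyl), so nothing can be read from them about any single change.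

Compound 3, `CN(C)CCCCCSC1=Nc2ccccc2C(CC(=O)NCc2ccccc2)N1c1ccc(-c2ccccc2)cc1`, is not yet measured. It differs from compound 1 in one place only: hydrogen in place of fluoro on an aromatic carbon; cut one bond further out, the change reads 4-fluorophenyl to phenyl. Among the measured compounds shown here, no measured pair isolates this change. A single fluorine removed from the outer ring of the biphenyl is a small edit, and the step in this assay is expected to be small, in no particular direction, and within the scatter; the expected step is a 1.1-fold lower number from compound 1 to compound 3 (0.03 log units; within the scatter). Compound 3 is therefore estimated at 8500 nM in this assay, with a range from 3500 nM to 20000 nM.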

Compound 3, half-maximal inhibitory concentration: 9600 nM
Compound 3: middle estimate off by 1.1-fold (0.05 log units), on the low side; measured number inside the range.
By their numbers in this assay, from the lowest: compounds 2, 1 and 3 (each within the scatter of the next).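

In this assay, among these compounds, the only single-place step so far is a 1.0-fold higher number from compound 1 to compound 3 (0.02 log units; within the scatter), so at this aromatic carbon, para to a large group, fluoro and hydrogen cannot be told apart by this read-out. Compound 1 and compound 2 differ at several places at once and could say nothing about any one position, whereas compound 1 and compound 3 isolate the 4-fluorophenyl to phenyl change and show that, in the setting of compound 1, the fluoro is not required for cytotoxicity at this level. Nothing available here bears on why the step is this small, and no explanation is offered.

Open at this position is what a larger or differently charged group, such as chloro, methoxy, an amine or a carboxylic acid, would do, since fluoro and hydrogen are the only two substituents shown. Also open, on these data alone, are the separate effects of the terminal amine and the benzyl amide, where compound 2 differs from compound 3 at more than one place, and of a shorter or longer chain between the sulfur and the amine.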